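This account rests on a few compounds, and the source may have more. Where it says the series, first, only, none or still open, it means among the compounds named here.

Measured so far in an assay on membranes from CHO cells for displacement of a labelled ligand from adenosine receptor A1 (Homo sapiens), read by scintillation counting, with a stated time of 60 min, tested at 1 uM; a lower number here means less inhibition, a higher number more inhibition at the concentration tested (going by the name of the read-out): compound 1 `CC1=C(C(=O)C2CC2)C(c2ccsc2)NC(=O)N1` gives 2%; compound 2 `CC1=C(C(=O)CC(C)C)C(c2ccsc2)NC(=O)N1` gives 37%; compound 3 `CC1=C(C(=O)NC(C)C)C(c2ccsc2)NC(=O)N1` gives 8%.

Compound 3 stands second highest of the three numbers, within the scatter of compound 1 and below compound 2, as a number 29 percentage points lower from compound 2 to compound 3 (beyond the scatter) shows. Compound 4 `CCC(CC)OC(=O)C1=C(C)NC(=O)NC1c1ccsc1` differs from compound 3 thus: (pentan-3-yl)oxy in place of isopropylamino on a carbonyl carbon. Among the measured compounds shown here, the steps bearing on this are a number 29 percentage points lower from compound 2 to compound 3 (beyond the scatter) and a number 6 percentage points higher from compound 1 to compound 3 (within the scatter), both exchanges at the same carbonyl carbon; no measured step replaces an amino group by an alkoxy group, so the direction is uncertain. Since compound 2 with isobutyl gave 37%, a partial return toward that number is expected. The estimated step is a number 12 percentage points higher from compound 3 to compound 4 (beyond the scatter). Compound 4 is expected to give 20% in this assay, within 0% to 45%.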

Compound 4, a percentage reported as inhibition, at one concentration (the size of the read-out at that concentration, not a potency): 22%
Compound 4: the middle estimate sits 2 percentage points below what was measured; the measured number falls inside the stated range.
By their numbers in this assay, from the lowest: compounds 1 and 3 (each within the scatter of the next); then compound 4; then compound 2.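

With (pentan-3-yl)oxy on the carbonyl carbon, this assay gives an intermediate reading, with a number 14 percentage points higher from compound 3 to compound 4 (beyond the scatter) and a number 15 percentage points lower from compound 2 to compound 4 (beyond the scatter). Against cyclopropyl, the same position shows a number 20 percentage points higher from compound 1 to compound 4 (beyond the scatter), so an oxygen-linked branched chain here retains more inhibition than isopropylamino or cyclopropyl, but less than isobutyl. Nothing measured accounts for this order of groups. The change from isopropylamino swaps the linking atom and the chain together, so their separate contributions remain unresolved. Methoxy or ethoxy on the same carbonyl carbon would help separate them.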